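The compounds below may be only part of what the source reports. "The series", "measured", "known", "first", "only" and "open" are said of these compounds alone.

Two compounds in this series have been through a physicochemical assay for lipophilicity (a lower number here means a more polar compound, a higher number a more lipophilic compound), so far, but only one of them returned a number. Compound 1, `O=C(NCC1CCCCC1)c1cnccc1NC(=O)c1cccc2ccccc12`, gives 6.1 in this assay. Compound 2, `O=C(NCC1CCC1)c1ncccc1NC(=O)c1ccnc2ccccc12`, carries a smaller ring on its amide arm and a differently placed ring nitrogen in its core, and in this assay compound 2 is recorded as "not determined" (no result reported), so there is no single number on which to stand, and nothing can be said about how compound 2 compares with compound 1.

Compound 3, `COc1ccc(NC(=O)c2ccnc3ccccc23)c(C(=O)NCC2CCC2)n1`, is the next compound to be measured. It differs from compound 2 in one place: methoxy in place of hydrogen on an aromatic carbon. Among the compounds with values here, because no step between two measured compounds is available here, the size of this change has to be judged from general experience rather than from anything within this set; a small upward step in this assay is expected, of a size that may or may not exceed the usual scatter. For compound 3 the estimated value in this assay is 5, with a range from 4 to 6.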

Compound 3, distribution coefficient: 5.9
Estimate against measurement, compound 3: 0.90 log units below; the measured number falls inside the stated range.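

In this assay compound 3 gives 5.9, but compound 2 has no single number, so no step can be read between compound 2 and compound 3. As far as these compounds go, how far methoxy in place of hydrogen moves this value therefore stays open. Nothing at hand offers an explanation for the value of compound 3.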